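The source may report more compounds than this note shows. Statements on the series, on what has been measured and on what is new or still open speak of the compounds shown alone.

Measured so far in an ADME assay on HEK293 cells (Homo sapiens) for cytotoxicity, with a stated time of 72 h (a lower number here means that less compound is needed, a higher number that more compound is needed for the effect), for the shared core:

- compound 1 `C=C[C@@](C)(/C=C/c1ccc(O)c(CO)c1)CCC=C(C)C` gives > 36600 nM 
- compound 2 `C=C[C@@](C)(/C=C/c1ccc(O)c(C=O)c1)CCC=C(C)C` gives > 36600 nM 
- compound 3 `C=C[C@@](C)(/C=C/c1ccc(O)c(/C=C/C(=O)O)c1)CCC=C(C)C` gives > 36600 nM 

Compound 3 stands at > 36600 nM as a limit of the assay and not a number. The whole series reads alike, with the limit of > 36600 nM in this assay, at which 3 of the 3 values shown sit, as its record. Among the compounds with values here, compound 4 `C=C[C@@](C)(/C=C/c1ccc(O)c(/C=C/c2ccc(F)cc2)c1)CCC=C(C)C` carries 4-fluorophenyl in place of carboxy on a double-bonded chain carbon bound to a double-bonded chain carbon as its one change. Within the data shown here, the steps that bear on it are a step that the two limits leave unreadable from compound 1 to compound 3 and a step that the two limits leave unreadable from compound 2 to compound 3 and also a step that the two limits leave unreadable from compound 1 to compound 2 in the same place. None of them has a readable size. Only a modest move toward a lower number is therefore expected in this assay and the rough estimate is an at least 1.2-fold lower number from compound 3 to compound 4 (0.08 log units; that floor lies within the scatter) for now. The estimated value for compound 4 is 30000 nM within a range of 8000 nM to 60000 nM and it may again read as a limit.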

Compound 4, half-maximal effective concentration: > 36600 nM
Compound 4 gave a limit, no number; the forecaster's own chance of this, stated with the estimate: 55%; at least 1.2-fold (0.08 log units) between middle value and limit.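

Compound 4 gives a limit and not a number, as do compounds 1, 2 and 3, so none of the steps among them can be read in this assay: the limit of > 36600 nM in this assay, at which 4 of the 4 values shown sit.

The compounds shown leave open what concentration any of the four needs for the effect, and whether any of these changes shifts it.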